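The source may report more compounds than this note shows. Statements on the series, on what has been measured and on what is new or still open speak of the compounds shown alone.

Measured so far in a functional assay on RXF 393 cells (Homo sapiens) for inhibition, read by sulforhodamine B assay, with a stated time of 48 h; a lower number here means a stronger inhibitor of growth, a higher number a weaker inhibitor of growth:
compound 1, `Nc1cc(N)c2nc(-c3ccccc3)c(NCc3ccc(Cl)c(Cl)c3)nc2c1`: 17000 nM
compound 3, `COc1cc(CNc2nc3cc(N)cc(N)c3nc2-c2ccccc2)cc(OC)c1OC`: 20000 nM
compound 2, `Nc1cc(N)c2nc(-c3ccccc3)c(Sc3ccc(F)cc3)nc2c1`: a limit only, see below.

For compound 2 the result < 100000 nM is a limit of this assay and not a number. Compound 2 sits at the limit of < 100000 nM in this assay, at which 1 of the 3 values shown sits.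

Compound 4, `Nc1cc(N)c2nc(-c3ccccc3)c(Sc3ccc(Cl)c(Cl)c3)nc2c1`, is still to be measured. It differs from compound 2 by 3,4-dichlorophenyl in place of 4-fluorophenyl on a sulfur. Within the data shown here, no step between measured compounds covers this change, so its size cannot be read from the data. Compound 1 gives 17000 nM and compound 3 gives 20000 nM, which mark the range where numbers have appeared. Compound 4 is expected near 25000 nM, within 6000 nM to 100000 nM. The step that the limit leaves unreadable from compound 2 to compound 4 is an expectation only, and a limit cannot be ruled out.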

Compound 4, concentration for total growth inhibition: 26900 nM
Estimate against measurement, compound 4: 1.1-fold (0.03 log units) below; low and high end bracket the measured number.
By their numbers in this assay, from the lowest: compounds 1, 3 and 4 (each within the scatter of the next).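

In this assay, among these compounds, compound 2 gives < 100000 nM, a limit and not a number, so no step from it to compound 4 can be read. Going by these compounds, what replacing 4-fluorophenyl with 3,4-dichlorophenyl on the sulfur does to growth inhibition stays open.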